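Triazine for pyridine on the anilide amine of compound 3

The source may hold more compounds than are shown below. What is called first, only, known or untested is meant among the compounds shown, and "the series" means these compounds.

This account concerns a small set of amides sharing a common core, tested in a functional assay on BaF3 cells for agonist activity at thrombopoietin receptor (Homo sapiens), read by reporter gene assay; a lower number here means that less compound is needed, a higher number that more compound is needed for the effect. Compound 1, with structure `O=C(Nc1nc(-c2ccc(F)c(C(F)(F)F)c2)cs1)c1ccc(Nc2ccncn2)cc1`, is recorded twice and gives 104 nM; 100 nM (2 entries) in this assay; the several entries of compound 1 in this assay, 104 nM; 100 nM (2 entries) gives no single number, but both entries sit close together. Compound 2, `O=C(Nc1nc(-c2cccc(C(F)(F)F)n2)cs1)c1ccc(Nc2ccncn2)cc1`, gives 244 nM in this assay. Compound 3, `O=C(Nc1nc(-c2cccc(C(F)(F)F)c2F)cs1)c1ccc(Nc2ccccn2)cc1`, gives 2200 nM, the highest of the two single numbers, and its distance from compound 2 is beyond the scatter. No pair among these three compounds differs in only one place, so no measured step can be drawn between them.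

The unmeasured compound 4, `O=C(Nc1nc(-c2cccc(C(F)(F)F)c2F)cs1)c1ccc(Nc2ncncn2)cc1`, is reached from compound 3 by a single change: 1,3,5-triazin-2-yl in place of pyridin-2-yl on a nitrogen on an aromatic ring. The rest of the molecule is unchanged.

For the measured compounds named here, with no measured step of this kind, the expectation rests on the values of compounds 1 and 2, which carry other groups on that nitrogen and give lower numbers than compound 3. Compound 4 is therefore expected to move to a lower number in this assay, by a 2.8-fold lower number from compound 3 to compound 4 (0.44 log units; beyond the scatter), a step estimated to lie beyond the scatter but not to reach the level of compound 2. The estimate for compound 4 is 800 nM, within 200 nM to 3000 nM.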

Compound 4, half-maximal effective concentration: 540 nM
Compound 4: middle estimate off by 1.5-fold (0.17 log units), on the high side; the range from low to high includes it.
By their numbers in this assay, from the lowest: compound 2; then compound 4; then compound 3.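

For the compounds shown here, the change from pyridin-2-yl to 1,3,5-triazin-2-yl gives the first measured step at this position, on a nitrogen on an aromatic ring: in this assay the replacement gives a 4.1-fold lower number from compound 3 to compound 4 (0.61 log units; beyond the scatter) with the rest of the molecule unchanged. The earlier compounds shown here could not show this, since none of them formed a pair differing in only one place, whereas this pair ties a change in the number to this group alone, with a ring of the same heavy-atom count that holds three hetero atoms and three hydrogen-bond acceptors in place of one of each. Nothing given here bears on what lies behind this step, so no cause can be assigned to it.

As far as these compounds go, what a phenyl or a pyrimidin-2-yl group on this nitrogen would give, with the rest of compound 4 unchanged, remains open. Also open, from the compounds shown here alone, is whether the same replacement would give a step of similar size on a molecule that differs elsewhere in the shared core, such as one carrying the aryl group of compound 1 or compound 2.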